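Cyclic sulfone replacing the ethoxyethyl ether

The source may hold more compounds than are shown below. What is called first, only, known or untested is meant among the compounds shown, and "the series" means these compounds.

Measured so far:
compound 1 `CCOCCOc1cc(C)c(-c2cccc(COc3ccc(CCC(=O)O)c(F)c3)c2)c(C)c1` — 4.5 nM
compound 2 `Cc1cc(OC2CCS(=O)(=O)CC2)cc(C)c1-c1cccc(COc2ccc(CCC(=O)O)c(F)c2)c1` — 25 nM

In a functional assay on CHO cells for agonist activity at Free fatty acid receptor 1 (Homo sapiens), read by FLIPR and calcium flux, with a stated time of 90 s, in the presence of a further agent that is not named here (a higher number here means that more compound is needed for the effect, a lower number that less compound is needed), compound 1 gives 4.5 nM, the lowest of the two numbers; compound 2 gives 25 nM, the step being a 5.6-fold higher number from compound 1 to compound 2 (0.74 log units; beyond the scatter). Compound 3 `Cc1cc(OCC2(O)CCS(=O)(=O)CC2)cc(C)c1-c1cccc(COc2ccc(CCC(=O)O)c(F)c2)c1` differs from compound 1 by 4-hydroxy-1,1-dioxothian-4-yl in place of ethoxymethyl on a saturated chain carbon bound to an oxygen on an aromatic ring. Going by the values given here, the only step that bears on this is a 5.6-fold higher number from compound 1 to compound 2 (0.74 log units; beyond the scatter), where the same cyclic sulfone ring stood directly on the aryl oxygen; compound 3 keeps that ring, now carrying a hydroxyl and linked through a methylene. A similar move is therefore expected, with compound 3 sitting near compound 2 and a step of a 5.6-fold higher number from compound 1 to compound 3 (0.74 log units; beyond the scatter) in the higher direction. Compound 3 is estimated at 25 nM, in the range 8 nM to 80 nM.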

Compound 3, half-maximal effective concentration in the Free fatty acid receptor 1 assay: 15 nM
Beside the measured number, compound 3's estimate is 1.7-fold (0.22 log units) above it; measured number inside the range.
By their numbers in the Free fatty acid receptor 1 assay, from the lowest: compound 1; then compounds 3 and 2 (each within the scatter of the next).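

In the Free fatty acid receptor 1 assay the (4-hydroxy-1,1-dioxothian-4-yl)methyl group does not recover the number of the 2-ethoxyethyl group (a 3.3-fold higher number from compound 1 to compound 3 (0.52 log units; beyond the scatter)), and it cannot be told from the 1,1-dioxothian-4-yl group (a 1.7-fold lower number from compound 2 to compound 3 (0.22 log units; within the scatter)). The sulfone ring therefore tolerates the added hydroxyl and methylene link on this oxygen. This modest step comes with a much larger change in a physicochemical assay for lipophilicity, read by HPLC; on this read-out lower numbers stand for lower lipophilicity and higher numbers for higher lipophilicity: the measured distribution coefficient of compound 1, 4.14, and of compound 3, 2.78, a number 1.36 log units lower (beyond the scatter). In the physicochemical assay compound 1 gives 4.14 and compound 3 gives 2.78.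

The compounds shown do not separate the contribution of the hydroxyl from that of the methylene link. On these data alone, whether an amine in place of the hydroxyl would bring the number in the Free fatty acid receptor 1 assay closer to that of compound 1 stays open.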